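A few compounds are considered here, and "the series" means these few. Any claim that something is new, unique, unknown or untested is made for them only; others in the source may bear on it.

Compound 1 `CC(C)c1nccc2nn(-c3ccccc3)cc12`: 98800 nM
Compound 2 `Cc1nc(CCO)cc2nn(-c3ccccc3)cc12`: a limit only

In a functional assay on MCF7 cells (Homo sapiens) for inhibition, read by fluorescence, with a stated time of 72 h (on this read-out higher numbers stand for weaker inhibition of growth and lower numbers for stronger inhibition of growth), compound 1 gives 98800 nM. Compound 2 reaches only a limit in this assay, > 100000 nM, meaning the measurement ended without a definite number. Among the two results, compound 1 therefore stands as the only one with a number, while the other sits at the limit of > 100000 nM in this assay, at which 1 of the 2 values shown sits. Both compounds share the same core and differ in the groups attached to it.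

Compound 3 `CCCCc1cc2nn(-c3ccccc3)cc2c(C(C)C)n1` has not yet been measured. Set against compound 1 it carries butyl in place of hydrogen on an aromatic carbon. Among the measured compounds shown here, no step between two measured compounds is available to lean on, so the expectation rests on compound 1 alone. Because compound 1 sits at 98800 nM, a weak result, a move toward somewhat stronger inhibition in this assay is expected, though it may not clear the usual scatter. The expected step from compound 1 to compound 3 is a 1.6-fold lower number from compound 1 to compound 3 (0.22 log units; within the scatter), an estimate rather than a measurement. Compound 3 is thus expected to give about 60000 nM in this assay, within a range from 20000 nM to 150000 nM.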

Compound 3, concentration for 50% growth inhibition: 33300 nM
Beside the measured number, compound 3's estimate is 1.8-fold (0.26 log units) above it, and the stated range covers the measured number.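

The two earlier compounds differ from each other in more than one place, so they could not single out any one position on the shared core. Among the compounds shown here, compound 3 is the first to isolate a single change: with butyl in place of hydrogen on an aromatic carbon, next to the ring nitrogen, this assay gives a 3.0-fold lower number from compound 1 to compound 3 (0.47 log units; beyond the scatter), which shows that this position tolerates a chain and that growth inhibition here becomes stronger rather than being lost. Nothing shown here explains why the butyl group goes with the lower number.

A single chain at a single position cannot show whether length matters, so a shorter ethyl chain, a longer hexyl chain, or a polar group such as an amine or a carboxylic acid at the same place could each move the number in either direction. From the compounds shown here alone, it also remains open whether the butyl group would give a similar step on a core carrying something other than the isopropyl group.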